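The source may report more compounds than this note shows. Statements on the series, on what has been measured and on what is new or still open speak of the compounds shown alone.

Measured so far in a functional assay on MCF7 cells (Homo sapiens) for cytotoxicity, read by MTT assay, with a stated time of 72 h; on this read-out lower numbers stand for stronger inhibition of growth and higher numbers for weaker inhibition of growth:
- compound 1, `COc1ccc(OC(=O)Nc2ccc([Se]C#N)cc2)cc1`: 22400 nM
- compound 2, `CCOC(=O)Nc1ccc([Se][Se]c2ccc(NC(=O)OCC)cc2)cc1`: 9900 nM
- compound 3, `CCCCCCOC(=O)Nc1ccc([Se]C#N)cc1`: 6600 nM

Compound 1 gives the highest number of the three in this assay. Compound 2 sits nearest to it, and the gap between compound 1 and compound 2 lies beyond the scatter; compound 3 sits furthest, and that gap too lies beyond the scatter. Among the measured compounds shown here, no pair among the three differs in a single place, so no step between measured compounds can be stated; the three values only show that the selenocyanate with a hexyl carbamate and the diselenide with ethyl carbamates give lower numbers than the aryl carbamate of compound 1.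

Compound 4, `N#C[Se]c1ccc(NC(=O)Oc2ccc(F)cc2)cc1`, is not yet measured. It differs from compound 1 by fluoro in place of methoxy on an aromatic carbon. For the measured compounds named here, nothing among the measured compounds speaks to this exchange, so no step beyond the scatter is expected from compound 1 to compound 4, with a slight lean toward a lower number. The step is estimated as a 1.2-fold lower number from compound 1 to compound 4 (0.09 log units; within the scatter). In this assay compound 4 is expected at 18000 nM, within the range 7000 nM to 45000 nM.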

Compound 4, concentration for 50% growth inhibition: 8300 nM
Estimate against measurement, compound 4: 2.2-fold (0.34 log units) above; low and high end bracket the measured number.
By their numbers in this assay, from the lowest: compounds 3, 4 and 2 (each within the scatter of the next); then compound 1.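

In this assay, the substituent on the aryl carbamate ring is not a silent position: fluoro in place of methoxy, on an aromatic carbon para to a large group, gives a 2.7-fold lower number from compound 1 to compound 4 (0.43 log units; beyond the scatter) and so moves the number beyond the scatter. Among the compounds shown here, this is the first exchange made at a single place, and it shows that this one change, with the selenocyanate and the carbamate held constant, is enough to shift growth inhibition. Which difference between the two groups matters cannot be told from this one pair, and no measurement beyond the growth read-out bears on the result.

On these data alone, whether chloro, methyl or a bare hydrogen at this place would sit with fluoro or with methoxy remains open. Also open, as far as these compounds go, is whether the same exchange gives a step of similar size at other places on this ring.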